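Working notes: from compound 2 to compound 3

A few compounds are considered here, and "the series" means these few. Any claim that something is new, unique, unknown or untested is made for them only; others in the source may bear on it.

Measured so far in a physicochemical assay for lipophilicity; on this read-out lower numbers stand for lower lipophilicity and higher numbers for higher lipophilicity
- compound 1 `COc1ccc(C2=[N+]3C(=Nc4c(-c5ccccc5)c5c(n4[B-]3(F)F)-c3ccc(OCC(=O)N[C@@H](CCC(=O)O)C(=O)O)cc3CC5)C(c3ccccc3)=C2I)cc1` with value -0.74
- compound 2 `COc1ccc2c(c1)CCc1c(-c3ccccc3)c3n(c1-2)[B-](F)(F)[N+]1=C(c2ccc(OCC(=O)O)cc2)C(I)=C(c2ccccc2)C1=N3` with value 0.92

Of these two, compound 2 holds the higher number in this assay and compound 1 the lower, with the gap beyond the scatter. The two differ in more than one place, so their gap does not isolate any single change.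

Compound 3 `COc1ccc2c(c1)CCc1c(-c3ccccc3)c3n(c1-2)[B-](F)(F)[N+]1=C(c2ccc(OCC(=O)N[C@@H](CC(=O)O)C(=O)O)cc2)C(I)=C(c2ccccc2)C1=N3` is still unmeasured. It has (1,2-dicarboxyethyl)amino in place of hydroxy on a carbonyl carbon of compound 2 ((1,2-dicarboxyethyl)amino in place of hydroxy on a carbonyl carbon). The same difference reads as carboxy to (1,2-dicarboxyethyl)carbamoyl.

Among the measured compounds shown here, no measured pair shows this change alone. The nearest guide is compound 1 (-0.74), whose side chain also has an amide ending in carboxy groups. A downward step in this assay, beyond the scatter, is therefore expected. The estimate is a number 1.72 log units lower from compound 2 to compound 3 (beyond the scatter) as the expected size. For compound 3 the estimated value is -0.8 with an expected range from -1.4 to -0.2 pending measurement.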

Compound 3, partition coefficient: -0.73
Estimate against measurement, compound 3: 0.07 log units below, within the range that was stated.
By their numbers in this assay, from the lowest: compounds 1 and 3 (each within the scatter of the next); then compound 2.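

In this assay, putting (1,2-dicarboxyethyl)amino in place of hydroxy on a carbonyl carbon gives a number 1.65 log units lower from compound 2 to compound 3 (beyond the scatter), a large step. Among the compounds shown here, the gap between the first two compounds spanned more than one place, so it could not be tied to any single change; this step is the first to isolate one change, here on the carbonyl carbon whose other neighbour is a saturated chain carbon. It shows that at this position the read-out responds strongly when the carboxymethyl end becomes ((1,2-dicarboxyethyl)carbamoyl)methyl, though no measurement on record bears on the cause of the step.

For the compounds shown here, the single step cannot separate the contribution of the new amide link from that of the two carboxy groups it brings, so a methylamino group, which gives the amide with no carboxylic acid, and a (carboxymethyl)amino group, which carries only one, would be the informative entries at this carbonyl carbon. Also open, going by these compounds, is whether a step of this size would recur with an amine-bearing chain in the same place or with the same change on a different core.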